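Longer Ester Chain on a Thromboxane Synthase Inhibitor Scaffold

The compounds below may be only part of what the source reports. "The series", "measured", "known", "first", "only" and "open" are said of these compounds alone.

Measured compounds:
Compound 1, `COc1ccc(COCC(Cn2ccnc2)OCc2ccc(OC)cc2)cc1`, gives 9900 nM in a functional assay for inhibition of Thromboxane-A synthase (Homo sapiens); on this read-out lower numbers stand for stronger inhibition and higher numbers for weaker inhibition.
Compound 2, `CCCOC(=O)c1ccc(COC(COCc2ccc(OC)cc2)Cn2ccnc2)cc1`, gives 180 nM in this assay.
Compound 3, `COc1ccc(COCC(Cn2ccnc2)OCc2ccc(C(=O)OCc3ccccc3)cc2)cc1`, gives 1490 nM in this assay.

Compound 1 has the highest number of the three, so it is the weakest inhibitor shown; compound 3 sits nearest to it and compound 2 furthest away. The new compound 4, `CCCCCCCCOC(=O)c1ccc(COC(COCc2ccc(OC)cc2)Cn2ccnc2)cc1`, differs from compound 1 in one place: octyloxycarbonyl in place of methoxy on an aromatic carbon.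

Two measured steps replace the same methoxy with an ester and therefore bear directly on this change. The step of a 55-fold lower number from compound 1 to compound 2 (1.74 log units; beyond the scatter) was large, while the step of a 6.6-fold lower number from compound 1 to compound 3 (0.82 log units; beyond the scatter) was modest. Between the two esters, the step of an 8.3-fold higher number from compound 2 to compound 3 (0.92 log units; beyond the scatter) shows that the alkyl ester gave the lower number. Compound 4 carries an alkyl ester as well, only longer, so a large drop in number is expected, probably closer to the behaviour of compound 2 than of compound 3. The step of a 33-fold lower number from compound 1 to compound 4 (1.52 log units; beyond the scatter) is the expected outcome. Compound 4 is therefore estimated at 300 nM, within 60 nM to 1500 nM.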

Compound 4, half-maximal inhibitory concentration: 21000 nM
Compound 4: middle estimate off by 70-fold (1.85 log units), on the low side; the measured number lies above the stated range.
By their numbers in this assay, from the lowest: compound 2; then compound 3; then compound 1; then compound 4.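

The step of a 2.1-fold higher number from compound 1 to compound 4 (0.33 log units; beyond the scatter) shows that an ester in this place does not by itself lower the number: octyloxycarbonyl is no improvement on methoxy. The step of a 120-fold higher number from compound 2 to compound 4 (2.07 log units; beyond the scatter) shows that a longer alkyl chain on the ester is enough to lose all the gain seen with propoxycarbonyl, and the step of a 14-fold higher number from compound 3 to compound 4 (1.15 log units; beyond the scatter) puts the octyl ester behind the benzyl ester as well. Nothing available explains why the octyl ester behaves so differently from the other two esters.

The only alkyl esters shown are propyl and octyl, so how the number changes across butyl, pentyl or hexyl esters remains open. Also open, going by these compounds, is how a methyl ester or a carboxylic acid would read in the same place.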